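Shortening the thioester on a pyrazole carboxamide chain

A few compounds are considered here, and "the series" means these few. Any claim that something is new, unique, unknown or untested is made for them only; others in the source may bear on it.

Measured compounds:
compound 1 `O=C(OCc1ccccc1)SCCCCCCNC(=O)c1cc(-c2ccncc2)n[nH]1`: 24700 nM
compound 2 `C=CCOC(=O)SCCCCCCNC(=O)c1cc(-c2ccncc2)n[nH]1`: 36000 nM
compound 3 `CCC(=O)SCCCCCCNC(=O)c1cc(-c2ccncc2)n[nH]1`: > 50000 nM

In a functional assay on MDA-MB-231 cells (Homo sapiens) for inhibition, read by MTT assay, with a stated time of 96 h (on this read-out lower numbers stand for stronger inhibition of growth and higher numbers for weaker inhibition of growth), compound 1 gives 24700 nM. Compound 2 gives 36000 nM in this assay, and the step of a 1.5-fold higher number from compound 1 to compound 2 (0.16 log units; within the scatter) leaves the two compounds indistinguishable. Compound 3 reaches only the limit of this assay, > 50000 nM, so no number is known for it (the limit of > 50000 nM in this assay, at which 1 of the 3 values shown sits). Among the two numbers shown, compound 1 thus holds the one that is not matched by a limit, with compound 2 within the scatter of it.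

Compound 4 `CC(=O)SCCCCCCNC(=O)c1cc(-c2ccncc2)n[nH]1` is not yet measured. It differs from compound 1 as follows: methyl in place of benzyloxy on a carbonyl carbon. The measured steps that bear on this change are an at least 2.0-fold higher number from compound 1 to compound 3 (0.30 log units; that floor lies within the scatter) and an at least 1.3-fold higher number from compound 2 to compound 3 (0.14 log units; that floor lies within the scatter), both of which replace an alkoxy group on the carbonyl carbon by a short alkyl and both of which end at the limit. Compound 4 carries an even shorter alkyl than compound 3, so a step from compound 1 in the direction of weaker inhibition of growth is expected, at least as large as the floor seen toward compound 3, and there is a good chance this assay will again report only a limit.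

The expected step is a 2.6-fold higher number from compound 1 to compound 4 (0.42 log units; beyond the scatter). Compound 4 is therefore estimated at 65000 nM, with a range from 30000 nM to 140000 nM.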

Compound 4, concentration for 50% growth inhibition: > 50000 nM
Compound 4 gave a limit, no number (the forecaster's own chance of this, stated with the estimate: 65%); the middle value lies beyond the limit too.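

Compound 4 also stands at a limit and not at a number in this assay: the limit of > 50000 nM in this assay, at which 2 of the 4 values shown sit.
Methyl in place of benzyloxy on a carbonyl carbon gives an at least 2.0-fold higher number from compound 1 to compound 4 (0.30 log units; that floor lies within the scatter), and methyl in place of allyloxy gives an at least 1.3-fold higher number from compound 2 to compound 4 (0.14 log units; that floor lies within the scatter); both floors lie within the scatter, so neither step alone establishes a real loss of growth inhibition. What the result adds is that a second short alkyl on this carbonyl carbon, methyl as well as ethyl, yields no number in this assay, while the step from compound 3 to compound 4 cannot be read and the two cannot be placed in any order.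

Going by these compounds, how far compound 3 and compound 4 lie past the limit stays open, and with it whether replacing the benzyloxy or allyloxy group by a short alkyl costs much or little. Also open, on these data alone, is whether a longer alkyl chain such as hexyl, or an amine, on this carbonyl carbon would give a measurable number and how that number would compare with those of compound 1 and compound 2.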